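The source may hold more compounds than are shown below. What is called first, only, known or untested is meant among the compounds shown, and "the series" means these compounds.

Compound 1 `C[C@@H]1CN(c2sc(C(F)(F)F)nc2-c2nc3ccccc3[nH]2)CCN1C(=O)Cn1ccc(C(=O)O)n1`: 2100 nM
Compound 2 `COC1CCN(CC(=O)N2CCN(c3sc(C(F)(F)F)nc3-c3nc4ccccc4[nH]3)C[C@H]2C)C1`: 42 nM
Compound 3 `Cc1nc(C)n(CC(=O)N2CCN(c3sc(C(F)(F)F)nc3-c3nc4ccccc4[nH]3)C[C@H]2C)n1`: 3.2 nM

All three compounds share one core and differ only in the group attached to a saturated chain carbon bound to a carbonyl carbon. In a functional assay on CHO-K1 cells for antagonist activity at C-X-C chemokine receptor type 3 (Homo sapiens), read by FLIPR, with a stated time of 10 min, in the presence of a further agent that is not named here (a higher number here means a weaker inhibitor, a lower number a stronger inhibitor), compound 3 gives the lowest number of the three and is the strongest inhibitor among them. Going from the 3-carboxy-1H-pyrazol-1-yl group of compound 1 to the 3,5-dimethyl-1H-1,2,4-triazol-1-yl group gives a 660-fold lower number from compound 1 to compound 3 (2.82 log units; beyond the scatter), and going from the 3-methoxypyrrolidin-1-yl group of compound 2 to the same triazole gives a 13-fold lower number from compound 2 to compound 3 (1.12 log units; beyond the scatter). Both steps show that this position swings the result widely and that the dimethyltriazole is the best of the three groups seen.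

Compound 4 `C[C@@H]1CN(c2sc(C(F)(F)F)nc2-c2nc3ccccc3[nH]2)CCN1C(=O)Cn1cnc2c1CCN(C)C2` carries the change (a group of 10 heavy atoms (7 carbon, 3 nitrogen; one five-membered aromatic ring with 2 hetero atoms, one six-membered non-aromatic ring with 1 hetero atom) in place of a group of 7 heavy atoms (4 carbon, 3 nitrogen; one five-membered aromatic ring with 3 hetero atoms), on a saturated chain carbon bound to a carbonyl carbon). It keeps a five-membered aromatic ring bound to that chain carbon, as compound 3 does, but adds a six-membered non-aromatic ring fused to it. Going by the values given here, no measured step covers such an enlargement; the two steps into compound 3 only show that the azole beats a carboxy-bearing pyrazole and a saturated ring. The expected step is a 3.1-fold higher number from compound 3 to compound 4 (0.49 log units; beyond the scatter), a slight weakening at most. Compound 4 is estimated at 10 nM, in a range from 2 nM to 60 nM.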

Compound 4, half-maximal inhibitory concentration in the C-X-C chemokine receptor type 3 assay: 3.6 nM
Beside the measured number, compound 4's estimate is 2.8-fold (0.44 log units) above it; the measured number falls inside the stated range.
By their numbers in the C-X-C chemokine receptor type 3 assay, from the lowest: compounds 3 and 4 (each within the scatter of the next); then compound 2; then compound 1.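

In the C-X-C chemokine receptor type 3 assay, enlarging the group on this saturated chain carbon bound to a carbonyl carbon costs nothing that can be read: a 1.1-fold higher number from compound 3 to compound 4 (0.05 log units; within the scatter) is inside the scatter, while compound 4 keeps the wide gaps to the other two, with a 12-fold lower number from compound 2 to compound 4 (1.07 log units; beyond the scatter) and a 580-fold lower number from compound 1 to compound 4 (2.77 log units; beyond the scatter). So the position takes more than the dimethyltriazole, and a six-membered non-aromatic ring can come along with a five-membered aromatic ring without a visible loss in this pair, which the earlier compounds could not show. The same change also separates the two compounds in a physicochemical assay for solubility, in simulated intestinal fluid (a higher number here means a more soluble compound, a lower number a less soluble compound), with an at least 2.0-fold higher number from compound 3 to compound 4 (0.32 log units; beyond the scatter). In the physicochemical assay compound 3 gives 440 ug/mL. In the physicochemical assay compound 4 gives > 920 ug/mL and this reading is a limit of the assay and not a number: the limit of > 920 ug/mL in the physicochemical assay, at which 1 of the 2 values shown sits.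

As far as these compounds go, whether the five-membered aromatic ring of compound 4 would give the same numbers on its own, or an open-chain amine on that chain carbon would do as well, stays open. Equally open, from the compounds shown here alone, is how large a group this position accepts, which a benzyl group or a morpholine ring in the same place would help to settle.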